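The source may hold more compounds than are shown below. What is called first, only, known or untested is meant among the compounds shown, and "the series" means these compounds.

Measured so far in an ADME assay on microsomes from liver (Homo sapiens) for metabolic stability, read by LC-MS, with a stated time of 10 min, tested at 0.5 uM; on this read-out higher numbers stand for a more stable compound and lower numbers for a less stable compound:
- compound 1 `c1ccc2c(c1)CN[C@@H](CN(CC1CCNCC1)[C@H]1CCCc3cccnc31)C2`: 86%
- compound 2 `c1ccc2c(c1)CN[C@@H](CN(CCC1CCNCC1)[C@H]1CCCc3cccnc31)C2`: 66%

Of these two, compound 2 stands lowest at 66%, and its gap to compound 1 lies beyond the scatter. Next for measurement is compound 3 `CCN1CCN(CCCN(C[C@H]2Cc3ccccc3CN2)[C@H]2CCCc3cccnc32)CC1`. The structural change is (4-ethylpiperazin-1-yl)methyl in place of piperidin-4-yl on a saturated chain carbon, two bonds along the chain from an amine nitrogen. Cut one bond further out, this reads 2-(piperidin-4-yl)ethyl to 3-(4-ethylpiperazin-1-yl)propyl.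

Going by the values given here, only one measured step bears on this change: a number 20 percentage points lower from compound 1 to compound 2 (beyond the scatter). That modest step put (piperidin-4-yl)methyl in place of piperidin-4-yl, so it covers the extension of the chain but not the exchange of the ring. Among the compounds with values here, no measured compound carries the 4-ethylpiperazin-1-yl group, which leaves its contribution open. A further fall of similar size is therefore expected, though with little support. The estimated move is a number 18 percentage points lower from compound 2 to compound 3 (beyond the scatter). For compound 3 the expected value in this assay is 48%, with an estimated range from 27% to 69%.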

Compound 3, percent of the compound remaining: 59%
The estimate for compound 3 lay 11 percentage points below the measured number, within the range that was stated.
By their numbers in this assay, from the lowest: compounds 3 and 2 (each within the scatter of the next); then compound 1.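

In this assay, exchanging 2-(piperidin-4-yl)ethyl for 3-(4-ethylpiperazin-1-yl)propyl gives a number 7 percentage points lower from compound 2 to compound 3 (within the scatter), so at this position the larger group with two ring hetero atoms and no hydrogen-bond donor reads the same as the piperidine-bearing chain of compound 2. Measured against the shorter chain of compound 1, the same group gives a number 27 percentage points lower from compound 1 to compound 3 (beyond the scatter), which means that among the three compounds, both longer side chains sit beyond the scatter from compound 1, and no compound shown goes against this. Nothing available explains either step.

Compound 3 differs from compound 2 in chain length, ring and ethyl group at once, so the shown values do not assign the result to any one of these parts. Still open, from the compounds shown here alone, is how a 3-(piperidin-4-yl)propyl chain, or a piperazin-1-yl ring without the ethyl group on the same propyl chain, would read in this assay, and whether a 2-(4-ethylpiperazin-1-yl)ethyl group on the shorter chain would come closer to compound 1.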